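Varying the aryl group on the acrylamide chain of a shared core

The compounds below may be only part of what the source reports. "The series", "measured", "known", "first", "only" and "open" are said of these compounds alone.

Compounds measured so far:
compound 1, `COc1ccc(OC)c(/C=C/C(=O)Nc2cc3c(Nc4ccc(F)c(Cl)c4)ncnc3cc2O[C@H]2CCOC2)c1`, 7300 nM
compound 2, `COc1cc(/C=C/C(=O)Nc2cc3c(Nc4ccc(F)c(Cl)c4)ncnc3cc2O[C@H]2CCOC2)cc(OC)c1O`, 27000 nM
compound 3, `O=C(/C=C/c1cccc(Cl)c1Cl)Nc1cc2c(Nc3ccc(F)c(Cl)c3)ncnc2cc1O[C@H]1CCOC1`, 23200 nM

All three compounds were tested in a functional assay on A549 cells (Homo sapiens) for cytotoxicity, read by MTT assay, with a stated time of 72 h; on this read-out higher numbers stand for weaker inhibition and lower numbers for stronger inhibition. Compound 3 stands second highest of the three numbers: its nearest neighbour is compound 2, where the difference of a 1.2-fold lower number from compound 2 to compound 3 (0.07 log units; within the scatter) lies within the scatter, and its furthest is compound 1, separated by a 3.2-fold higher number from compound 1 to compound 3 (0.50 log units; beyond the scatter).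

Compound 4, `COc1cc(/C=C/C(=O)Nc2cc3c(Nc4ccc(F)c(Cl)c4)ncnc3cc2O[C@H]2CCOC2)cc(OC)c1OC`, has not yet been measured. It differs from compound 3 in one place: 3,4,5-trimethoxyphenyl in place of 2,3-dichlorophenyl on a double-bonded chain carbon bound to a double-bonded chain carbon. Going by the values given here, two measured steps bear on this change, both of which swap the aryl group on a double-bonded chain carbon bound to a double-bonded chain carbon. The step of a 3.2-fold higher number from compound 1 to compound 3 (0.50 log units; beyond the scatter) was modest; the step of a 1.2-fold lower number from compound 2 to compound 3 (0.07 log units; within the scatter) was within the scatter. The 3,4,5-trimethoxyphenyl of compound 4 resembles the 4-hydroxy-3,5-dimethoxyphenyl of compound 2 more than the 2,5-dimethoxyphenyl of compound 1, so the expected step for compound 4 in this assay is a 1.3-fold lower number from compound 3 to compound 4 (0.11 log units; within the scatter), a slightly lower number but not clearly beyond the scatter. Compound 4 is therefore estimated at 18000 nM, in a range of 6000 nM to 50000 nM.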

Compound 4, half-maximal inhibitory concentration: 4150 nM
Beside the measured number, compound 4's estimate is 4.3-fold (0.64 log units) above it; the measured number lies below the stated range.
By their numbers in this assay, from the lowest: compounds 4 and 1 (each within the scatter of the next); then compounds 3 and 2 (each within the scatter of the next).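

In this assay, going by these compounds alone, the step of a 6.5-fold lower number from compound 2 to compound 4 (0.81 log units; beyond the scatter) shows that methyl in place of hydrogen on an oxygen on an aromatic ring is enough to move the number, so this aryl group responds to one small change and not only to the exchange of a whole aryl group, which was all the earlier compounds showed. The 3,4,5-trimethoxyphenyl group also separates from 2,3-dichlorophenyl, with a 5.6-fold lower number from compound 3 to compound 4 (0.75 log units; beyond the scatter), while its step from 2,5-dimethoxyphenyl, a 1.8-fold lower number from compound 1 to compound 4 (0.25 log units; within the scatter), places the two aryl groups that carry only methoxy groups at one level, and compound 2, with its hydroxy group, stands apart from them. No measured evidence here accounts for these steps.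

The compounds shown leave open whether a longer chain in place of the methyl on that oxygen would hold the level of compound 4. They also leave open how an amine or a carboxylic acid on this aromatic ring would compare.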